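From phenyl to pyridin-2-yl on an amide-type nitrogen

This account rests on a few compounds, and the source may have more. Where it says the series, first, only, none or still open, it means among the compounds named here.

Compound 1 `CC(=O)c1ccc(N2CCN(c3nc(=O)c4cc(C(F)(F)F)cc([N+](=O)[O-])c4s3)CC2)cc1` and compound 2 `O=C(CN1CCN(c2nc(=O)c3cc(C(F)(F)F)cc([N+](=O)[O-])c3s2)CC1)Nc1ccccc1` share a core and differ in one side group. In a toxicity assay on HeLa cells (Homo sapiens) for cytotoxicity, read by colorimetric assay, with a stated time of 72 h (on this read-out higher numbers stand for lower toxicity in this test and lower numbers for higher toxicity in this test), compound 1 gives > 105000 nM as a limit of the assay and not as a number. Among the compounds with values here, compound 2 gives > 101000 nM as a limit too, so it has no exact figure, and the only other value shown is also a limit.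

Compound 3 `O=C(CN1CCN(c2nc(=O)c3cc(C(F)(F)F)cc([N+](=O)[O-])c3s2)CC1)Nc1ccccn1` keeps the shared core and changes one place, with pyridin-2-yl in place of phenyl on an amide-type nitrogen as the whole difference from compound 2. Within the data shown here, one measured step bears on this, a step that the two limits leave unreadable from compound 1 to compound 2 as the only comparison available, and it offers no size to carry over.

The expectation therefore rests on compound 2 at > 101000 nM as a limit. In this assay no change beyond the usual scatter is expected, and the expected size is a number no higher from compound 2 to compound 3 (the limit leaves the size open) as an estimate. Compound 3 is estimated at 100000 nM with an expected range of 50000 nM to 200000 nM on this read-out, and it may again appear only as a limit.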

Compound 3, half-maximal cytotoxic concentration: 44500 nM
Estimate against measurement, compound 3: 2.2-fold (0.35 log units) above; measured number below the stated range.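

In this assay, pyridin-2-yl in place of phenyl on the amide-type nitrogen gives an at least 2.2-fold lower number from compound 2 to compound 3 (0.35 log units; beyond the scatter), a shift towards higher toxicity in this test, so this place does respond to a swap that keeps the heavy-atom count and exchanges one ring carbon for nitrogen, something the earlier limits could not show. Measured against the other side group, ((pyridin-2-yl)carbamoyl)methyl in place of 4-acetylphenyl on the ring amine nitrogen gives an at least 2.3-fold lower number from compound 1 to compound 3 (0.37 log units; beyond the scatter), while the step between the two earlier compounds cannot be read. From the compounds shown here alone, the first of these sizes stays open-ended because compound 2 stands at a limit of the assay and not at a number: the limit of > 101000 nM in this assay, at which 1 of the 3 values shown sits.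

The compounds shown leave open whether a pyridin-4-yl ring, or a phenyl ring carrying an amine or a carboxylic acid, on the same amide-type nitrogen would lower the number in the same way. They also offer no explanation for the change, and a single pair cannot show whether pyridin-2-yl would have the same effect on another core.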